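Compound 1 and an untested swap of one end group

The compounds below may be only part of what the source reports. "The series", "measured", "known", "first", "only" and "open" are said of these compounds alone.

compound 1 `COc1ccc(Oc2ccc(C(C)C)cc2-c2ccsc2S(=O)(=O)NCCNC(=S)Nc2ccc([N+](=O)[O-])cc2)cc1OC`: 11900 nM
compound 2 `COc1ccc(NC(=O)NCCNS(=O)(=O)c2ccc(-c3ccccc3OCc3ccccc3)s2)cc1`: > 50000 nM
compound 3 `COc1ccc(Oc2ccc([N+](=O)[O-])cc2-c2ccsc2S(=O)(=O)N2CCN(C(=S)Nc3ccc(Cl)cc3)CC2)cc1OC`: > 50000 nM

Among the compounds with values here, in a functional assay on HeLa cells (Homo sapiens) for inhibition, read by CCK-8 assay, with a stated time of 48 h (a higher number here means a weaker inhibitor, a lower number a stronger inhibitor), compound 1 gives 11900 nM, the only true number so far. Compound 2 reads > 50000 nM, which is a limit and not a number. Compound 3 reads > 50000 nM, which is also a limit.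

Compound 4 `COc1ccc(Oc2ccc(C(C)C)cc2-c2ccsc2S(=O)(=O)NCCNC(=O)Nc2cc(Cl)cc(Cl)c2)cc1OC` keeps the core of compound 1 and changes one piece: a group of 11 heavy atoms (7 carbon, 1 nitrogen, 1 oxygen, 2 chlorine; one six-membered aromatic ring of carbon only) in place of a group of 12 heavy atoms (7 carbon, 2 nitrogen, 2 oxygen, 1 sulfur; one six-membered aromatic ring of carbon only), on an amine nitrogen. Within the data shown here, no measured pair isolates this swap. The estimate therefore stays close to compound 1 at 11900 nM, the sole numerical anchor in this assay. A small move towards weaker inhibition, within the usual scatter, is expected, namely a 1.5-fold higher number from compound 1 to compound 4 (0.18 log units; within the scatter). For compound 4 the estimated value is 18000 nM, with an expected range from 6000 nM to 45000 nM.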

Compound 4, half-maximal inhibitory concentration: 11600 nM
For compound 4 the middle estimate is 1.6-fold (0.19 log units) above the measured one, and the stated range covers the measured number.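

Putting (3,5-dichlorophenyl)carbamoyl on the amine nitrogen in place of the earlier end group gives a 1.0-fold lower number from compound 1 to compound 4 (0.01 log units; within the scatter) in this assay. The shared core thus keeps its reading with two quite different end groups at this position. The earlier compounds shown here could not show this, as compound 2 and compound 3 each differ from compound 1 in more than one place.

Going by these compounds, whether an amine or a carboxylic acid in place of this end group would shift the reading stays open. Any loss of strength would be hard to size because the scale stops at a limit: the limit of > 50000 nM in this assay, at which 2 of the 4 values shown sit.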